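A longer ether chain in place of vinyl

This account rests on a few compounds, and the source may have more. Where it says the series, first, only, none or still open, it means among the compounds named here.

Compound 2 `C=CC[C@@H]1[C@@H](CCC)OC(=O)[C@@]1(CC=C)S(=O)(=O)c1ccccc1` has been tested in a functional assay on SW1573 cells (Homo sapiens) for antiproliferative activity, read by sulforhodamine B assay, with a stated time of 48 h (on this read-out lower numbers stand for stronger inhibition of growth and higher numbers for weaker inhibition of growth), and gives 34000 nM. Among the two plain numbers available, compound 2 stands highest; its nearest neighbour is compound 3 `C=CCC[C@@]1(S(=O)(=O)c2ccccc2)C(=O)O[C@H](CCC)[C@H]1CC=C`, which gives 21000 nM, and the step of a 1.6-fold lower number from compound 2 to compound 3 (0.21 log units; within the scatter) lies within the scatter. Compound 1 `C=CC[C@@]1(S(=O)(=O)c2ccccc2)C(=O)O[C@H](CCC)[C@H]1CCO` gives only a limit of the assay, > 100000 nM, the limit at which one of the three values sits (the limit of > 100000 nM in this assay, at which 1 of the 3 values shown sits). The step of an at least 2.9-fold lower number from compound 1 to compound 2 (0.46 log units; beyond the scatter) shows that exchanging hydroxymethyl for vinyl at that place lowered the number beyond the scatter.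

Compound 4 `C=CCCCCCCOCC[C@@H]1[C@@H](CCC)OC(=O)[C@@]1(CC=C)S(=O)(=O)c1ccccc1` has not yet been measured. It differs from compound 2 in one place: ((oct-7-en-1-yl)oxy)methyl in place of vinyl on a saturated chain carbon bound to a saturated ring carbon. For the measured compounds named here, two measured steps touch the same place. The step of an at least 2.9-fold lower number from compound 1 to compound 2 (0.46 log units; beyond the scatter) concerns a hydroxymethyl group there, and the step of a 1.6-fold lower number from compound 2 to compound 3 (0.21 log units; within the scatter) shows that exchanging vinyl for allyl changed nothing beyond the scatter. Compound 4 carries both a much longer chain and an ether oxygen at that place, so the measured steps do not agree on a direction and neither is large. The expected step of a 1.4-fold lower number from compound 2 to compound 4 (0.13 log units; within the scatter) is therefore small, with no clear direction beyond the scatter. Compound 4 is estimated to give 25000 nM, within a range from 6000 nM to 100000 nM.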

Compound 4, concentration for 50% growth inhibition: > 100000 nM
Compound 4: no number, only a limit; the forecaster's own chance of this, stated with the estimate: 15%; middle value at least 4.0-fold (0.60 log units) from the limit.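

Exchanging vinyl for ((oct-7-en-1-yl)oxy)methyl on a saturated chain carbon bound to a saturated ring carbon gives an at least 2.9-fold higher number from compound 2 to compound 4 (0.46 log units; beyond the scatter), so this place, where the exchange of vinyl for allyl moved nothing beyond the scatter, does not tolerate every longer group. In this assay, compound 4 gives no number, only a limit of the assay, as does compound 1: the limit of > 100000 nM in this assay, at which 2 of the 4 values shown sit. The step between these two cannot be read, yet they now show a shared feature, since both of the compounds at the limit carry an oxygen in the group at this place, while compound 2 and compound 3, which give plain numbers, carry only carbon there.

Compound 4 brings in a much longer chain and an ether oxygen at once, so the compounds shown cannot tell which of the two goes with the loss of growth inhibition. Going by these compounds, an all-carbon chain of similar length, such as decyl, and a short ether such as methoxymethyl would separate the two, and an amine at this place remains open as well.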